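Losing a chloro on an inactive core pair

The compounds below may be only part of what the source reports. "The series", "measured", "known", "first", "only" and "open" are said of these compounds alone.

Compound 1 `O=C1COc2ccc(-c3cnc(Cl)c(NS(=O)(=O)c4ccc(F)cc4)c3)cc2N1c1ccc(Cl)cc1` and compound 2 `O=C1COc2ccc(-c3cnc(Cl)c(NS(=O)(=O)c4ccc(F)cc4)c3)cc2N1c1ccccc1` share one core; compound 3 `O=C1COc2ccc(-c3cnc4ccccc4c3)cc2N1c1ccc(Cl)cc1` and compound 4 `O=C1COc2ccc(-c3cnc4ccccc4c3)cc2N1c1ccccc1` share another, and the difference between the two cores is not broken down here. In a functional assay on MCF7 cells (Homo sapiens) for antiproliferative activity, read by MTT assay, with a stated time of 72 h (on this read-out lower numbers stand for stronger inhibition and higher numbers for weaker inhibition), compound 1 gives 32800 nM. For compound 2 the read-out is only a limit of the assay, > 40000 nM. For compound 3 the read-out is likewise a limit, > 40000 nM. The change from compound 1 to compound 2 is hydrogen in place of chloro on an aromatic carbon and it made a step of an at least 1.2-fold higher number from compound 1 to compound 2 (0.08 log units; that floor lies within the scatter). The change from compound 3 to compound 4 is hydrogen in place of chloro on an aromatic carbon, the same change at the same kind of place. Both measured cores sit at or near (the limit of > 40000 nM in this assay, at which 2 of the 3 values shown sit), so the earlier step sets only a floor on how far the number rose. On that basis compound 4 is expected to move by about a step that the limit leaves unreadable from compound 3 to compound 4, staying at the limit. The number estimated for compound 4 is therefore 50000 nM, with a range from 30000 nM to 120000 nM in this assay.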

Compound 4, half-maximal inhibitory concentration: > 40000 nM
Compound 4 ended at the assay's limit; the forecaster's own chance of this, stated with the estimate: 85%; the middle value is on the limit's open side.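

No step can be read from compound 3 to compound 4 in this assay, because both compounds stand at a limit of the assay and not at a number: the limit of > 40000 nM in this assay, at which 3 of the 4 values shown sit. The compounds shown leave open whether going from 4-chlorophenyl to phenyl changes the read-out on this core at all, and what numbers lie beyond that limit for either compound.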